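The compounds below may be only part of what the source reports. "The series", "measured", "known", "first", "only" and "open" are said of these compounds alone.

Measured in a functional assay on HCT-116 cells (Homo sapiens) for antiproliferative activity, read by sulforhodamine B assay, with a stated time of 72 h; on this read-out higher numbers stand for weaker inhibition and lower numbers for stronger inhibition:
compound 1 (`Cn1ncc(Cl)c1-c1cc(C(=O)N[C@@H]2CN[C@H](CCCO)C[C@H]2c2ccc(Cl)c(Cl)c2)oc1Cl`) gives 510 nM
compound 2 (`Cn1ncc(Cl)c1-c1cc(C(=O)N[C@@H]2CN[C@H](CC(=O)O)C[C@H]2c2ccc(Cl)c(Cl)c2)oc1Cl`) gives 4020 nM
compound 3 (`Cn1ncc(Cl)c1-c1cc(C(=O)N[C@@H]2CN[C@H](CC(=O)NCC(O)CO)C[C@H]2c2ccc(Cl)c(Cl)c2)oc1Cl`) gives 7090 nM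

Compound 3 belongs with compound 2 at the weak end of this small set, and only compound 1 stands clearly apart. The two side chains with a carbonyl both sit well off the alcohol chain, with steps of (a 7.9-fold higher number from compound 1 to compound 2 (0.90 log units; beyond the scatter)) and (a 14-fold higher number from compound 1 to compound 3 (1.14 log units; beyond the scatter)).

Next is compound 4 (`Cn1ncc(Cl)c1-c1cc(C(=O)N[C@@H]2CN[C@H](CC(=O)NC3CC3)C[C@H]2c2ccc(Cl)c(Cl)c2)oc1Cl`), with cyclopropyl in place of 2,3-dihydroxypropyl on an amide-type nitrogen. Among the compounds with values here, no measured step makes this exact change. The closest evidence is the change on the same carbonyl carbon (a 1.8-fold higher number from compound 2 to compound 3 (0.25 log units; within the scatter)), which stayed within the scatter. The larger steps involve the whole chain and only mark how far the number might fall. In this assay a modest step to a lower number is therefore expected, though a result within the scatter of compound 3 would not surprise. The estimated value for compound 4 is 3000 nM (expected range 900 nM to 8000 nM), an expected (a 2.4-fold lower number from compound 3 to compound 4 (0.37 log units; beyond the scatter)).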

Compound 4, half-maximal inhibitory concentration: 740 nM
Beside the measured number, compound 4's estimate is 4.1-fold (0.61 log units) above it; the measured number lies below the stated range.
By their numbers in this assay, from the lowest: compounds 1 and 4 (each within the scatter of the next); then compounds 2 and 3 (each within the scatter of the next).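

In this assay the group on the amide-type nitrogen proves to matter: cyclopropyl in place of 2,3-dihydroxypropyl gives a step beyond the scatter (a 9.6-fold lower number from compound 3 to compound 4 (0.98 log units; beyond the scatter)), whereas the earlier change on the carbonyl carbon stayed within it. A side-chain carbonyl alone therefore does not fix the number at the weak end, as cyclopropylamino in place of hydroxy also shows (a 5.4-fold lower number from compound 2 to compound 4 (0.73 log units; beyond the scatter)). The amide and the alcohol chain now cannot be told apart (a 1.5-fold higher number from compound 1 to compound 4 (0.16 log units; within the scatter)).

Going by these compounds, whether the ring or the loss of the two hydroxy groups drives the step stays open, and an ethyl, a 2-hydroxyethyl or a cyclobutyl on the same nitrogen would separate the two. No measurement shown here bears on the reason for this step.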